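Fluoro in place of hydrogen: compound 1 to compound 3

A few compounds are considered here, and "the series" means these few. Any claim that something is new, unique, unknown or untested is made for them only; others in the source may bear on it.

Compound 1 `CCCCc1cc2ccccc2nc1-c1cc(-c2ccccc2)no1` gives in a functional assay on PC-3 cells (Homo sapiens) for inhibition, read by MTT assay, with a stated time of 24 h (a lower number here means a stronger inhibitor, a higher number a weaker inhibitor), only a limit, > 100000 nM. Compound 2 `CCCCCc1cc2ccccc2nc1-c1cc(-c2ccccc2)no1` likewise gives only a limit in this assay, > 100000 nM. The step that the two limits leave unreadable from compound 1 to compound 2 cannot be sized, as both values sit at the limit (the limit of > 100000 nM in this assay, at which 2 of the 2 values shown sit). Compound 3 `CCCCc1cc2ccccc2nc1-c1cc(-c2ccc(F)cc2)no1` differs from compound 1 by fluoro in place of hydrogen on an aromatic carbon. No measured step covers this change, and the single step shown, a step that the two limits leave unreadable from compound 1 to compound 2, is unreadable, so no direction can be drawn for compound 3. Compound 3 is therefore expected to stay at the limit in this assay, with an estimated step that the limit leaves unreadable from compound 1 to compound 3, giving an expected value of 150000 nM (range 50000 nM to 500000 nM).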

Compound 3, half-maximal inhibitory concentration: 26300 nM
For compound 3 the middle estimate is 5.7-fold (0.76 log units) above the measured one; the measured number lies below the stated range.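

In this assay, within the data shown here, the change from phenyl to 4-fluorophenyl gives an at least 3.8-fold lower number from compound 1 to compound 3 (0.58 log units; beyond the scatter) and yields the only number that is not a limit. The aromatic carbon para to a large group therefore responds to substitution, which the unreadable chain step between compound 1 and compound 2 could not show. The step has only a lower bound, since compound 1 stands as a limit: the limit of > 100000 nM in this assay, at which 2 of the 3 values shown sit.

Going by these compounds, whether an amine or a carboxylic acid on the same carbon would move the number further remains open. So does whether fluoro gives a readable value on compound 2.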